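Working notes: biaryl amide acid series, HepG2 cytotoxicity

This account rests on a few compounds, and the source may have more. Where it says the series, first, only, none or still open, it means among the compounds named here.

Compound 1 `CC(C)N(Cc1cccc(OCCCCCC(=O)O)c1)C(=O)c1ccc(-c2cccc(OCc3ccccc3)c2)cc1`: > 26000 nM
Compound 2 `CCOc1cccc(-c2ccc(C(=O)N(Cc3cccc(OCCCCCC(=O)O)c3)C(C)C)cc2)c1`: > 20800 nM
Compound 3 `CC(C)N(Cc1cccc(OCCCCCC(=O)O)c1)C(=O)c1ccc(-c2cccc(O)c2)cc1`: > 26000 nM

In an ADME assay on HepG2 cells (Homo sapiens) for cytotoxicity, read by CellTiter-Glo and resazurin assay, with a stated time of 72 h (a lower number here means that less compound is needed, a higher number that more compound is needed for the effect), compound 1 gives > 26000 nM, which is a limit of the assay and not a number. Compound 2 likewise reaches only a limit, > 20800 nM. Compound 3 also stops at a limit, > 26000 nM. Compound 1 therefore sits at the limit of > 26000 nM in this assay, at which 2 of the 3 values shown sit, shared with compound 3, while compound 2 sits at the limit of > 20800 nM in this assay, at which 1 of the 3 values shown sits. Every value in the set is a limit, so the steps a step that the two limits leave unreadable from compound 1 to compound 2, a step that the two limits leave unreadable from compound 1 to compound 3 and a step that the two limits leave unreadable from compound 2 to compound 3 have no readable size.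

Compound 4 `CC(C)N(Cc1cccc(OCCCCCC(=O)O)c1)C(=O)c1ccc(-c2cccc(S(C)(=O)=O)c2)cc1` differs from compound 1 by methylsulfonyl in place of benzyloxy on an aromatic carbon. The step from compound 1 to compound 3, hydrogen in place of benzyl on an oxygen on an aromatic ring, is the closest measured change, but its size is not readable, and the two remaining steps give no size either. No step beyond the scatter can be expected in this assay in either direction; a further limit is the likeliest outcome. For compound 4 the expected value is 30000 nM (range 15000 nM to 60000 nM), an expected step that the limit leaves unreadable from compound 1 to compound 4.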

Compound 4, half-maximal effective concentration: > 26000 nM
Compound 4: only a limit was reported; the forecaster's own chance of this, stated with the estimate: 85%; the middle value does not contradict the limit.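

In this assay compound 4 gives > 26000 nM, a limit of the assay and not a number. Its steps from compound 1, compound 2 and compound 3, all limits as well, cannot be read. The compounds shown leave open whether any substituent at this aromatic carbon changes the half-maximal effective concentration.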